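The source may report more compounds than this note shows. Statements on the series, on what has been measured and on what is new or still open speak of the compounds shown alone.

Of the compounds shown here, three have been measured so far, and a fourth awaits measurement. Compound 1 `O=C1/C(=C/c2ccccc2F)CN(Cc2cn(Cc3ccccc3F)nn2)C/C1=C\c1ccccc1F` and compound 2 `O=C1/C(=C/c2ccccc2F)CN(Cc2cn(Cc3ccccc3Cl)nn2)C/C1=C\c1ccccc1F` share one core and differ only in the group on the benzyl ring. In a functional assay on MCF7 cells (Homo sapiens) for cytotoxicity, read by MTT assay, with a stated time of 24 h (a higher number here means a weaker inhibitor, a lower number a stronger inhibitor), compound 1 gives 6000 nM. In this assay compound 2 gives 10000 nM. The change from compound 2 to compound 1 is fluoro in place of chloro on an aromatic carbon, and it made a 1.7-fold lower number from compound 2 to compound 1 (0.22 log units; within the scatter).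

Compound 3 `COc1ccc(/C=C2\CN(Cc3cn(Cc4ccccc4Cl)nn3)C/C(=C\c3ccc(OC)cc3)C2=O)cc1` carries the same 2-chlorobenzyl group as compound 2 on a different core; how the two cores differ is not broken down here. In this assay compound 3 gives only a limit, > 100000 nM, and this is the limit of > 100000 nM in this assay, at which 1 of the 3 values shown sits.

Compound 4 `COc1ccc(/C=C2\CN(Cc3cn(Cc4ccccc4F)nn3)C/C(=C\c3ccc(OC)cc3)C2=O)cc1` is the compound still to be measured in this assay. It differs from compound 3 by fluoro in place of chloro on an aromatic carbon, the same change as that made between compound 2 and compound 1, at a place described in the same words. Resting on a 1.7-fold lower number from compound 2 to compound 1 (0.22 log units; within the scatter), a step of similar small size is expected here, a number no higher from compound 3 to compound 4 (the limit leaves the size open). In this assay compound 4 is therefore estimated at 100000 nM, most likely reported again only as a limit, with a plausible range from 40000 nM to 300000 nM.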

Compound 4, half-maximal inhibitory concentration: >= 100000 nM
Compound 4 was reported as a limit; the forecaster's own chance of this, stated with the estimate: 80%; the middle value sits exactly at the limit.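

In this assay, compound 3 and compound 4 are both reported only as limits, not as numbers, and the step between them cannot be read. The compounds shown leave open whether the change from 2-chlorobenzyl to 2-fluorobenzyl on this core shifts the number at all, and how far the true values of compound 3 and compound 4 lie from their limits.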